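A few compounds are considered here, and "the series" means these few. Any claim that something is new, unique, unknown or untested is made for them only; others in the source may bear on it.

Compound 1 `CN(C)c1nc(/C=C/c2ccccc2)nc2ccsc12`: > 1000000 nM
Compound 2 `C(=C/c1nc(Nc2ccccc2)c2sccc2n1)\c1ccccc1`: > 1000000 nM
Compound 3 `CN(c1ccccc1)c1nc(/C=C/c2ccccc2)nc2ccsc12`: > 1000000 nM

In a functional assay on L02 cells (Homo sapiens) for inhibition, read by Griess assay, with stated times of 1 h and 24 h (on this read-out higher numbers stand for weaker inhibition and lower numbers for stronger inhibition), compound 2 stands at > 1000000 nM, which is a limit and not a number. All three compounds share one reading: the limit of > 1000000 nM in this assay, at which 3 of the 3 values shown sit.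

The unmeasured compound 4 `Brc1ccc(CNc2nc(/C=C/c3ccccc3)nc3ccsc23)cc1` has 4-bromobenzyl in place of phenyl on a nitrogen on an aromatic ring. The measured changes at that nitrogen are a step that the two limits leave unreadable from compound 1 to compound 2, a step that the two limits leave unreadable from compound 1 to compound 3 and a step that the two limits leave unreadable from compound 2 to compound 3. None has a readable size, so they give no firm direction. Only a modest strengthening, if any, is expected in this assay, and a reading at the same limit remains likely. The estimated step is an at least 1.4-fold lower number from compound 2 to compound 4 (0.15 log units; that floor lies within the scatter). For compound 4 the estimate is 700000 nM, with an expected range of 60000 nM to 1500000 nM.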

Compound 4, half-maximal inhibitory concentration: > 1000000 nM
Compound 4: no number, only a limit; the forecaster's own chance of this, stated with the estimate: 65%; at least 1.4-fold (0.15 log units) between middle value and limit.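

No step can be read between compound 2 and compound 4, since each gives only a limit and not a number: the limit of > 1000000 nM in this assay, at which 4 of the 4 values shown sit. The compounds shown leave open whether any group on that nitrogen gives a measurable value in this assay.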